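Swapping Isobutyl for Fluorophenyl on the Weakest Compound

The source may report more compounds than this note shows. Statements on the series, on what has been measured and on what is new or still open speak of the compounds shown alone.

Measured so far:
compound 1 `CC(C)CCN(CCCCCCC(=O)NO)c1ncc(C(=O)NCc2cccnc2)s1`: 220 nM
compound 2 `O=C(/C=C/c1ccc(CN(Cc2ccc(F)cc2)c2ncc(C(=O)NCCCn3ccnc3)s2)cc1)NO`: 14 nM
compound 3 `CC(C)CCN(CCCCCCC(=O)NO)c1ncc(C(=O)NCCCn2ccnc2)s1`: 15 nM

All three were tested in an assay on isolated protein for inhibition of Nicotinamide phosphoribosyltransferase (Homo sapiens), read by fluorescence, with stated times of 5 min and 15 min; a lower number here means a stronger inhibitor, a higher number a weaker inhibitor. Among them compound 1 stands highest, meaning it is the weakest inhibitor of the set; its nearest neighbour is compound 3, and compound 2 lies a little further away. Among the compounds with values here, the only single-point step measured so far, a 15-fold lower number from compound 1 to compound 3 (1.17 log units; beyond the scatter), concerns the amide end of the molecule and not the side to be changed here.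

Compound 4 `O=C(CCCCCCN(Cc1ccc(F)cc1)c1ncc(C(=O)NCc2cccnc2)s1)NO` is obtained from compound 1 by the change (4-fluorophenyl in place of isobutyl on a saturated chain carbon bound to a nitrogen on an aromatic ring). Within the data shown here, no measured step tests this change on its own. Compound 2 does carry the same 4-fluorobenzyl group on that nitrogen, yet it differs from compound 1 in other places too, so its lower number cannot be assigned to this group alone.

Among the measured compounds shown here, with no direct precedent, the step of a 1.5-fold lower number from compound 1 to compound 4 (0.17 log units; within the scatter) is expected to stay small, likely within the scatter. Compound 4 is therefore estimated at 150 nM, with a range from 50 nM to 500 nM.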

Compound 4, half-maximal inhibitory concentration: 470 nM
Compound 4: middle estimate off by 3.1-fold (0.50 log units), on the low side, within the range that was stated.
By their numbers in this assay, from the lowest: compounds 2 and 3 (each within the scatter of the next); then compound 1; then compound 4.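

In this assay, within the data shown here, the change from isopentyl to 4-fluorobenzyl brings a 2.1-fold higher number from compound 1 to compound 4 (0.33 log units; beyond the scatter) and shows, for the first time, that this side of compound 1 responds to a single change, with the aromatic group giving weaker inhibition. The step is modest beside a 15-fold lower number from compound 1 to compound 3 (1.17 log units; beyond the scatter) at the amide end, so in these two pairs the amide end moves the number more than this side does. No measurement given here accounts for the rise. The compounds shown leave open whether the same swap would also raise the number on compound 3, which carries the imidazole-bearing amide. Also open, from the compounds shown here alone, is how a plain benzyl group, without the fluorine, or a longer chain on that nitrogen would compare with isopentyl and 4-fluorobenzyl.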